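From 2-(dimethylamino)ethyl to 3-(dimethylamino)propyl in compound 3

The source may report more compounds than this note shows. Statements on the series, on what has been measured and on what is new or still open speak of the compounds shown alone.

Compound 1 `CN(C)CCCn1c(N)c(-c2nc3ccccc3[nH]2)c2nc(C#N)c(C#N)nc21`: 8360 nM
Compound 2 `CN(C)CCCn1c(N)c(-c2nc3ccccc3o2)c2nc(C#N)c(C#N)nc21`: 5880 nM
Compound 3 `CN(C)CCn1c(N)c(-c2nc3cc(Cl)ccc3[nH]2)c2nc(C#N)c(C#N)nc21`: > 50000 nM, a limit and not a number

In an ADME assay on HEK293 cells (Homo sapiens) for cytotoxicity, read by MTT assay, with a stated time of 48 h (a higher number here means a weaker inhibitor, a lower number a stronger inhibitor), compound 3 stands at the limit of > 50000 nM in this assay, at which 1 of the 3 values shown sits, so there is only a limit for it and no exact value.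

Compound 4 `CN(C)CCCn1c(N)c(-c2nc3cc(Cl)ccc3[nH]2)c2nc(C#N)c(C#N)nc21` differs from compound 3 in its side chain: (dimethylamino)methyl in place of dimethylamino on a saturated chain carbon, two bonds along the chain from an aromatic nitrogen. Cut one bond further out, the same difference reads 2-(dimethylamino)ethyl to 3-(dimethylamino)propyl.

Among the compounds with values here, no measured step changes this chain. Within the data shown here, the only measured step, a 1.4-fold lower number from compound 1 to compound 2 (0.15 log units; within the scatter), swaps in 1,3-benzoxazol-2-yl for 1H-benzimidazol-2-yl at another place and stays within the scatter. Among the measured compounds shown here, it suggests only that the two compounds carrying the longer chain read alike in this assay.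

The better guide is the chain itself. Compound 1 gives 8360 nM with the 3-(dimethylamino)propyl chain, and compound 2 gives 5880 nM with the same chain. Neither carries the chlorine shared by compound 3 and compound 4, so the comparison is imperfect.

A lower number is therefore expected, and the estimated change is an at least 4.1-fold lower number from compound 3 to compound 4 (0.61 log units; beyond the scatter). For compound 4 the estimate is 12000 nM, with an expected range from 4000 nM to 45000 nM.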

Compound 4, half-maximal inhibitory concentration: 11700 nM
Compound 4: middle estimate off by 1.0-fold (0.01 log units), on the high side; the measured number falls inside the stated range.
By their numbers in this assay, from the lowest: compounds 2, 1 and 4 (each within the scatter of the next). At a limit, above all of these: compound 3.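

In this assay, the change from 2-(dimethylamino)ethyl to 3-(dimethylamino)propyl gives an at least 4.2-fold lower number from compound 3 to compound 4 (0.63 log units; beyond the scatter), the first sign among these compounds that the length of this chain goes with a change beyond the scatter. The true size of that step stays unknown because compound 3 has only a limit and not a number: the limit of > 50000 nM in this assay, at which 1 of the 4 values shown sits.

With the longer chain in place, the other two comparisons stay within the scatter, at a 1.4-fold higher number from compound 1 to compound 4 (0.15 log units; within the scatter) and a 2.0-fold higher number from compound 2 to compound 4 (0.30 log units; within the scatter), so neither the added chloro nor the swap from 1,3-benzoxazol-2-yl to 5-chloro-1H-benzimidazol-2-yl shows a clear change here.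

The compounds shown leave open whether the shorter chain would give a similar step with 1H-benzimidazol-2-yl lacking the chloro, since the one chain comparison carries that chlorine. They also leave open how the number would respond to a still longer chain, such as 4-(dimethylamino)butyl, or to diethylamino in place of dimethylamino at the chain end.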